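The compounds below may be only part of what the source reports. "The series", "measured", "known", "first", "only" and "open" are said of these compounds alone.

In a functional assay on the whole organism with Rattus norvegicus as the target (on this read-out higher numbers stand for an effect only at larger amounts of compound and lower numbers for an effect already at smaller amounts), compound 1 `CNc1cc(OC)c(C(=O)NC2CCN(Cc3ccccc3)C2)cc1Cl` gives 0.016 mg/kg and compound 3 `COc1cc(NC=O)c(Cl)cc1C(=O)NC1CCN(Cc2ccccc2)C1` gives 0.6 mg/kg on the same core. Compound 2 `COc1cc(NCc2ccccc2)c(Cl)cc1C(=O)NC1CCN(Cc2ccccc2)C1` gives > 30 mg/kg as a limit of the assay and not a number. Compound 3 thus holds the higher of the two true numbers, with a 38-fold higher number from compound 1 to compound 3 (1.57 log units; beyond the scatter) as the step that separates them.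

Compound 4 `COc1cc(NC(C)=O)c(Cl)cc1C(=O)NC1CCN(Cc2ccccc2)C1` differs from compound 3 by methyl in place of hydrogen on a carbonyl carbon in one place: methyl in place of hydrogen on a carbonyl carbon, which turns formylamino into acetamido. Within the data shown here, no measured step makes this change itself. The nearest evidence comes from changes on the same nitrogen, where an at least 1800-fold higher number from compound 1 to compound 2 (3.27 log units; beyond the scatter) and an at least 50-fold lower number from compound 2 to compound 3 (1.69 log units; beyond the scatter) are both large. Those steps exchange whole groups, while compound 4 keeps the carbonyl, so a far smaller effect is expected here, and the direction is expected to be towards a higher number. The expected change is a 2.5-fold higher number from compound 3 to compound 4 (0.40 log units; beyond the scatter) and would be modest. For compound 4 the estimated value is 1.5 mg/kg with an expected range from 0.3 mg/kg to 8 mg/kg in this assay when measured.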

Compound 4, dose for half-maximal effect: 1.8 mg/kg
Beside the measured number, compound 4's estimate is 1.2-fold (0.08 log units) below it; measured number inside the range.
By their numbers in this assay, from the lowest: compound 1; then compound 3; then compound 4. At a limit, above all of these: compound 2.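

Adding a single methyl on the carbonyl carbon, which turns formylamino into acetamido, gives in this assay a 3.0-fold higher number from compound 3 to compound 4 (0.48 log units; beyond the scatter), so even this small change at the carbonyl carbon moves the number beyond the scatter. Against the methyl on the same nitrogen, acetyl gives a 110-fold higher number from compound 1 to compound 4 (2.05 log units; beyond the scatter), a larger step in the same direction as the one formyl gave. Against benzyl, acetyl gives an at least 16-fold lower number from compound 2 to compound 4 (1.22 log units; beyond the scatter), and that step starts from compound 2, whose value is a limit and not a number: the limit of > 30 mg/kg in this assay, at which 1 of the 4 values shown sits.

Going by these compounds, whether a longer chain on the carbonyl carbon would carry the number further up or bring it back down stays open. Also open, on these data alone, is how an amine on that carbonyl carbon, or an ethyl group in place of the acyl group on the nitrogen, would read.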